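Removing the chlorine from the benzyl group of compound 3

A few compounds are considered here, and "the series" means these few. Any claim that something is new, unique, unknown or untested is made for them only; others in the source may bear on it.

Measured compounds:
- compound 1 `CS(=O)(=O)Nc1ccc2c(c1)S(=O)(=O)N=C(C1=C(O)C3CCCC3N(Cc3ccc(F)cn3)C1=O)N2` gives > 1 h in an in vitro ADME assay on microsomes from liver (Homo sapiens) for metabolic stability; on this read-out lower numbers stand for a shorter-lived compound and higher numbers for a longer-lived compound; this is a limit of the assay, not a number.
- compound 2 `CC(C)CCN1C(=O)C(C2=NS(=O)(=O)c3cc(NS(C)(=O)=O)ccc3N2)=C(O)C2CCCC21` gives 0.167 h in this assay.
- compound 3 `CS(=O)(=O)Nc1ccc2c(c1)S(=O)(=O)N=C(C1=C(O)C3CCCC3N(Cc3ccc(Cl)cc3)C1=O)N2` gives > 1 h in this assay; this is a limit of the assay, not a number.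

Compound 3 therefore stands at the upper limit of what this assay reports, together with compound 1 (the limit of > 1 h in this assay, at which 2 of the 3 values shown sit). The change to compound 4 `CS(=O)(=O)Nc1ccc2c(c1)S(=O)(=O)N=C(C1=C(O)C3CCCC3N(Cc3ccccc3)C1=O)N2` is hydrogen in place of chloro on an aromatic carbon. Among the compounds with values here, none of the measured steps touches this group: an at least 5.9-fold higher number from compound 2 to compound 3 (0.77 log units; beyond the scatter) and a step that the two limits leave unreadable from compound 1 to compound 3 both swap the whole group on the saturated chain carbon bound to the amide-type nitrogen, and the second of them cannot be read because both values are limits. Within the data shown here, the only readable steps concern the isobutyl compound 2, which is far from the change here. Compound 4 is therefore expected to stay close to compound 3, with a step that the limit leaves unreadable from compound 3 to compound 4 as the estimated step, and most likely to be reported again as a limit. The estimate for compound 4 is 1.2 h, within 0.5 h to 3 h.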

Compound 4, half-life: 0.833 h
Beside the measured number, compound 4's estimate is 1.4-fold (0.16 log units) above it; the range from low to high includes it.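

In this assay, hydrogen in place of chloro on the aromatic carbon gives an at least 1.2-fold lower number from compound 3 to compound 4 (0.07 log units; that floor lies within the scatter), so the chlorine is not shown to be needed for a long half-life. Even without it, the benzyl compound stays clearly apart from the isobutyl compound, with a 5.0-fold higher number from compound 2 to compound 4 (0.70 log units; beyond the scatter). Against the 5-fluoropyridin-2-yl compound there is an at least 1.2-fold lower number from compound 1 to compound 4 (0.07 log units; that floor lies within the scatter), and neither this step nor the one from the chloro compound can be given a true size because of where those two compounds sit: the limit of > 1 h in this assay, at which 2 of the 4 values shown sit.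

On these data alone, how far compounds 1 and 3 really lie from compound 4 stays open. As far as these compounds go, it is also open whether a methoxy group, a fluorine or a nitrile on that same aromatic carbon would give a half-life different from that of compound 4.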